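This account rests on a few compounds, and the source may have more. Where it says the series, first, only, none or still open, it means among the compounds named here.

In a functional assay on the whole organism for inhibition, with Brassica rapa subsp. chinensis as the target, with a stated time of 3 days, tested at 100 ppm (a higher number here means more inhibition of growth at the concentration tested, a lower number less inhibition of growth), compound 3 `CC(C)c1ccc(/C=C/C(=O)OCCc2ccccc2)cc1` gives 36%. Among the three measured compounds it stands second highest: compound 2 `CC(C)=CCCC(C)CCOC(=O)/C=C/c1ccc(C(C)C)cc1` gives 39%, and a number 3 percentage points lower from compound 2 to compound 3 (within the scatter); compound 1 `CCCOC(=O)/C=C/c1ccc(C(C)C)cc1` gives 8%, and a number 28 percentage points higher from compound 1 to compound 3 (beyond the scatter). Compound 4 `CC(C)c1ccc(/C=C/C(=O)OCCOc2ccccc2)cc1` differs from compound 3 in one place: phenoxy in place of phenyl on a saturated chain carbon, two bonds along the chain from an oxygen next to a carbonyl group. All three measured steps alter this same place, the saturated chain carbon two bonds along the chain from an oxygen next to a carbonyl group. Replacing methyl there with a larger group raised inhibition, as seen in a number 31 percentage points higher from compound 1 to compound 2 (beyond the scatter) and in a number 28 percentage points higher from compound 1 to compound 3 (beyond the scatter), while exchanging one larger group for another gave a number 3 percentage points lower from compound 2 to compound 3 (within the scatter). Going by the values given here, no measured step exchanges phenyl for phenoxy, so nothing in these data shows that a single oxygen added at this place moves the number beyond the scatter. Compound 4 is expected to show a step of a number 1 percentage points lower from compound 3 to compound 4 (within the scatter), which lies within the scatter. In this assay compound 4 is therefore estimated at 35%, with a range from 15% to 55%.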

Compound 4, percent growth inhibition at one concentration: 32%
Compound 4: middle estimate off by 3 percentage points, on the high side, and the stated range covers the measured number.
By their numbers in this assay, from the lowest: compound 1; then compounds 4, 3 and 2 (each within the scatter of the next).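

In this assay, phenoxy in place of phenyl on the saturated chain carbon, two bonds along the chain from an oxygen next to a carbonyl group, gives a step that stays within the scatter (a number 4 percentage points lower from compound 3 to compound 4 (within the scatter)), so the extra oxygen and the one hydrogen-bond acceptor that phenoxy counts do not separate these two compounds. Phenoxy also cannot be told apart from 1,5-dimethylhex-4-en-1-yl (a number 7 percentage points lower from compound 2 to compound 4 (within the scatter)), yet it stands clear of methyl (a number 24 percentage points higher from compound 1 to compound 4 (beyond the scatter)). Going by these compounds alone, compounds 2, 3 and 4 thus form one group beyond the scatter from compound 1, and this now holds for a substituent containing oxygen as well as for the two made only of carbon and hydrogen, with no compound here going against it. Nothing measured here accounts for these numbers.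

From the compounds shown here alone, whether an amine or a carboxylic acid at this place would move the number beyond the scatter remains open, as does the effect of a longer chain carrying the phenoxy group. Going by these compounds, it is also open whether a chlorine atom on the phenoxy ring would separate such a compound from compound 4.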